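The source may report more compounds than this note shows. Statements on the series, on what has been measured and on what is new or still open speak of the compounds shown alone.

Measured in an assay on isolated protein for inhibition of activin receptor type-2A (Homo sapiens), read by 33P incorporation, with a stated time of 20 min, in the presence of a further agent that is not named here; a lower number here means a stronger inhibitor, a higher number a weaker inhibitor:

compound 1 `COc1cc(-c2cnn3cc(OC)c(-c4cnn(C)c4)nc23)ccn1` — 530 nM
compound 2 `COc1cc(-c2cnn3cc(OC)c(-c4cc(C)no4)nc23)ccn1` — 3000 nM
compound 3 `COc1cc(-c2cnn3cc(OC)c(C4CCOC4)nc23)ccn1` — 1900 nM

Compound 3 stands second highest of these three numbers. Its nearest neighbour is compound 2, and a 1.6-fold lower number from compound 2 to compound 3 (0.20 log units; within the scatter) falls within the scatter, so the two cannot be ordered. Its furthest neighbour is compound 1, and a 3.6-fold higher number from compound 1 to compound 3 (0.55 log units; beyond the scatter) lies beyond the scatter.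

Compound 4 `COc1cc(-c2cnn3cc(OC)c(C)nc23)ccn1` differs from compound 3 in one place: methyl in place of oxolan-3-yl on an aromatic carbon. Among the measured compounds shown here, the steps that bear on this are a 5.7-fold higher number from compound 1 to compound 2 (0.75 log units; beyond the scatter) and a 3.6-fold higher number from compound 1 to compound 3 (0.55 log units; beyond the scatter), both modest rises when the 1-methyl-1H-pyrazol-4-yl was exchanged. For the measured compounds named here, no measured step removes the ring altogether, so the expectation for compound 4 is a small rise or none beyond the scatter, a 1.6-fold higher number from compound 3 to compound 4 (0.20 log units; within the scatter). Compound 4 is thus estimated at 3000 nM, with a range from 1200 nM to 8000 nM.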

Compound 4, half-maximal inhibitory concentration: 1200 nM
Compound 4: the middle estimate sits 2.5-fold (0.40 log units) above what was measured; low and high end bracket the measured number.
By their numbers in this assay, from the lowest: compound 1; then compounds 4, 3 and 2 (each within the scatter of the next, the first and the last beyond it).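

Replacing oxolan-3-yl with methyl on this aromatic carbon removes the ring, yet the two compounds cannot be told apart: a 1.6-fold lower number from compound 3 to compound 4 (0.20 log units; within the scatter). Methyl also does better than 3-methyl-1,2-oxazol-5-yl, with a 2.5-fold lower number from compound 2 to compound 4 (0.40 log units; beyond the scatter), so a ring here is not needed for this level of inhibition, whereas 1-methyl-1H-pyrazol-4-yl does better than methyl, with a 2.3-fold higher number from compound 1 to compound 4 (0.35 log units; beyond the scatter). No measurement is available that explains these differences. Open, going by these compounds, is how a longer chain or an amine on this carbon would compare with methyl. Also open, on these data alone, is whether any other ring could improve on compound 1.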